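The compounds below may be only part of what the source reports. "The series", "measured", "known", "first", "only" and "open" are said of these compounds alone.

Values measured in an ADME assay for permeability, using PAMPA, with a stated time of 4 h, at pH 7.4; on this read-out lower numbers stand for lower permeability and higher numbers for higher permeability:
- compound 1 `NCCCCN(C[C@@H]1Cc2cccnc2CN1)[C@H]1CCCc2cccnc21` gives 77 nm/s
- compound 2 `CN(C[C@@H]1Cc2ncccc2CN1)[C@H]1CCCc2cccnc21` gives 1000 nm/s
- compound 3 `NC(=O)NCCCCN(C[C@H]1Cc2ncccc2CN1)[C@H]1CCCc2cccnc21` gives 2 nm/s

Compound 3 has the lowest of the three numbers, beyond the scatter from both others. Compound 4 `c1cnc2c(c1)CN[C@@H](CN(CCCCNC1CCOCC1)[C@H]1CCCc3cccnc31)C2` carries oxan-4-yl in place of carbamoyl on an amine nitrogen, and the count reads (oxan-4-yl in place of carbamoyl on an amine nitrogen). Within the data shown here, no measured pair here shows the effect of this change, so the expectation rests on the spread of values alone. Compound 3 stands at 2 nm/s at the bottom of that spread, and the nearest number is that of compound 1 at 77 nm/s, so a rise beyond the scatter is expected in this assay. The expected change is a 15-fold higher number from compound 3 to compound 4 (1.18 log units; beyond the scatter). Compound 4 is estimated at 30 nm/s, with an expected range of 5 nm/s to 180 nm/s.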

Compound 4, apparent permeability: 8 nm/s
Estimate against measurement, compound 4: 3.8-fold (0.57 log units) above, and the stated range covers the measured number.
By their numbers in this assay, from the lowest: compound 3; then compound 4; then compound 1; then compound 2.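

In this assay, among these compounds, oxan-4-yl in place of carbamoyl on an amine nitrogen gives a 4.0-fold higher number from compound 3 to compound 4 (0.60 log units; beyond the scatter), the first comparison in this set of two compounds that differ in one place. The step is modest but beyond the scatter, so the read-out does respond to the group at this position. No measurement given here accounts for the step. Going by these compounds, it remains open how an acetyl or methylsulfonyl group on the same nitrogen would read, and whether the step would hold on a shorter chain.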